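Swapping the sulfonyl for a benzoyl on the indole-type nitrogen

The source may report more compounds than this note shows. Statements on the series, on what has been measured and on what is new or still open speak of the compounds shown alone.

Measured so far:
compound 1 `O=C1COCCN1c1ccc(/N=C\c2c[nH]c3ccccc23)cc1` gives 104%
compound 2 `Cc1ccc(S(=O)(=O)n2cc(/C=N\c3ccc(N4CCOCC4=O)cc3)c3ccccc32)cc1` gives 56.7%

Both were read in an ADME assay on BV-2 cells (Mus musculus) for cytotoxicity, read by MTT assay, with a stated time of 48 h, tested at 20 uM; a lower number here means a stronger effect, a higher number a weaker effect of the compound at the concentration tested. Among the compounds with values here, compound 2 stands lowest of the two numbers; the nearest is compound 1, and the single step, a number 47.3 percentage points lower from compound 1 to compound 2 (beyond the scatter), is a large one beyond the scatter. Compound 3 `O=C1COCCN1c1ccc(/N=C\c2cn(C(=O)c3ccccc3)c3ccccc23)cc1` is not yet measured. Its change from compound 2 is benzoyl in place of (4-methylphenyl)sulfonyl on an aromatic nitrogen. Within the data shown here, the only step that bears on this is the one from compound 1 to compound 2, where a large group entered at the same aromatic nitrogen and the number fell by a large amount; in compound 3 a large group stays on that nitrogen, only of a different kind. A small step is therefore expected, likely back toward compound 1 but well short of it, so that compound 3 is estimated at 70% with a range from 50% to 95%. This corresponds to an expected step of a number 13.3 percentage points higher from compound 2 to compound 3 (beyond the scatter).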

Compound 3, a percentage reported as activity, at one concentration (the size of the read-out at that concentration, not a potency): 85.1%
Compound 3: middle estimate off by 15.1 percentage points, on the low side, within the range that was stated.
By their numbers in this assay, from the lowest: compound 2; then compound 3; then compound 1.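

In this assay, the kind of group on this aromatic nitrogen proves to matter, not only whether a large group sits there: benzoyl in place of (4-methylphenyl)sulfonyl gives a number 28.4 percentage points higher from compound 2 to compound 3 (beyond the scatter), so the two groups are not interchangeable. Benzoyl in place of hydrogen still gives a number 18.9 percentage points lower from compound 1 to compound 3 (beyond the scatter), which places benzoyl on this nitrogen between hydrogen and (4-methylphenyl)sulfonyl in these three compounds. Nothing available here accounts for the difference between the two groups.

As far as these compounds go, it remains open where a methyl or an acetyl on this nitrogen would fall relative to hydrogen and benzoyl. From the compounds shown here alone, it is equally open whether a methoxy group, an amine or a carboxylic acid on the benzoyl ring would move the number in either direction.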